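This account rests on a few compounds, and the source may have more. Where it says the series, first, only, none or still open, it means among the compounds named here.

Measured so far in an ADME assay (liver) for metabolic stability, with Liver microsome (Homo sapiens) as the target, using microsomes and NADPH, with a stated time of 30 min, tested at 1 uM; on this read-out higher numbers stand for fast clearance and lower numbers for slow clearance:
- Compound 1 `COc1cc(C(O)(C(F)(F)F)C(F)(F)F)cnc1N1CCN(S(=O)(=O)c2ccc(N)nc2)CC1`: < 14 mL.min-1.g-1, a limit.
- Compound 2 `COCC#Cc1cc(C(O)(C(F)(F)F)C(F)(F)F)cnc1N1CCN(S(=O)(=O)c2ccc(N)nc2)CC1`: 15 mL.min-1.g-1.
- Compound 3 `Nc1ccc(S(=O)(=O)N2CCN(c3ncc(C(O)(C(F)(F)F)C(F)(F)F)cc3-c3ccoc3)CC2)cn1`: < 14 mL.min-1.g-1, a limit.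

Compound 3 stands on (the limit of < 14 mL.min-1.g-1 in this assay, at which 2 of the 3 values shown sit), so no number is known for it. The next change gives compound 4 `CS(=O)(=O)c1ccc(-c2cc(C(O)(C(F)(F)F)C(F)(F)F)cnc2N2CCN(S(=O)(=O)c3ccc(N)nc3)CC2)cc1`, with 4-(methylsulfonyl)phenyl in place of furan-3-yl on an aromatic carbon.

Going by the values given here, no measured compound carries 4-(methylsulfonyl)phenyl, so the guide is limited to the other replacements at this place. The step of an at least 1.0-fold higher number from compound 1 to compound 2 (0.02 log units; that floor lies within the scatter) and the step of an at least 1.0-fold lower number from compound 2 to compound 3 (0.02 log units; that floor lies within the scatter) give only floors, and both lie within the scatter. The step that the two limits leave unreadable from compound 1 to compound 3 gives no size at all.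

Among the compounds with values here, the one true number, for compound 2, is 15 mL.min-1.g-1 in this assay. All three substituents therefore leave the read-out in the same low region, and no step beyond the scatter is expected here. This expectation is weak, as it rests on three compounds and on limits. The expected change is a number no lower from compound 3 to compound 4 (the limit leaves the size open). Compound 4 could also return only a limit. For compound 4 the estimated value is 14 mL.min-1.g-1, with an expected range from 9 mL.min-1.g-1 to 28 mL.min-1.g-1.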

Compound 4, intrinsic clearance in microsomes: 32 mL.min-1.g-1
Beside the measured number, compound 4's estimate is 2.3-fold (0.36 log units) below it; the whole stated range lies below it.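

In this assay this position, on an aromatic carbon ortho to a large group, proves sensitive to its substituent, with 4-(methylsulfonyl)phenyl in place of furan-3-yl giving an at least 2.2-fold higher number from compound 3 to compound 4 (0.35 log units; beyond the scatter). The same holds against the other two groups, with a 2.1-fold higher number from compound 2 to compound 4 (0.33 log units; beyond the scatter) and an at least 2.2-fold higher number from compound 1 to compound 4 (0.35 log units; beyond the scatter), so compound 4 alone among the four stands clear of the others on this read-out, and it is the fastest-clearing of them. The steps starting from compound 1 and compound 3 are only floors, with their true size open, because both compounds rest on a limit: the limit of < 14 mL.min-1.g-1 in this assay, at which 2 of the 4 values shown sit.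

On these data alone, whether the higher number goes with the six-membered aromatic ring, with the methylsulfonyl group or with the larger substituent as a whole stays open. A plain phenyl ring, or a phenyl ring carrying an amine or a carboxylic acid in place of methylsulfonyl, would bear on that question, while the order among compound 1, compound 2 and compound 3 remains unresolved.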